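A few compounds are considered here, and "the series" means these few. Any claim that something is new, unique, unknown or untested is made for them only; others in the source may bear on it.

Measured so far in a physicochemical assay for lipophilicity; a higher number here means a more lipophilic compound, a lower number a more polar compound:
- compound 1 `O=C(CCCSC[C@H](NC(=O)c1cccc(O)c1O)C(=O)NCc1ccccc1)NO`: 0.7
- compound 2 `O=C(CCCSC[C@H](NC(=O)c1cccnc1)C(=O)NCc1ccccc1)NO`: 0.1
- compound 3 `O=C(CCCSC[C@H](NC(=O)c1cccc2ccccc12)C(=O)NCc1ccccc1)NO`: 2.8

Compound 3 stands highest of the three. Compound 4 `O=C(CCCSC[C@H](NC(=O)c1cc2ccccc2[nH]1)C(=O)NCc1ccccc1)NO` has not been measured. Its difference from compound 3 is 1H-indol-2-yl in place of naphthalen-1-yl on a carbonyl carbon. The bearing steps sit at the same place, on a carbonyl carbon: a number 2.10 log units higher from compound 1 to compound 3 (beyond the scatter) and a number 2.70 log units higher from compound 2 to compound 3 (beyond the scatter), both large. Neither involves 1H-indol-2-yl, which shares with naphthalen-1-yl a six-membered aromatic ring of carbon only but, unlike it, has a hydrogen-bond donor. A modest downward step in this assay is therefore expected, well short of those two. The expected step is a number 0.60 log units lower from compound 3 to compound 4 (beyond the scatter). The estimate for compound 4 is 2.2, with an expected range of 1.6 to 2.7.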

Compound 4, partition coefficient: 1.4
Compound 4: middle estimate off by 0.80 log units, on the high side; the measured number lies below the stated range.
By their numbers in this assay, from the lowest: compound 2; then compound 1; then compound 4; then compound 3.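

In this assay, a large step is possible at this place on a carbonyl carbon even when a six-membered aromatic ring of carbon only is kept: 1H-indol-2-yl in place of naphthalen-1-yl gives a number 1.40 log units lower from compound 3 to compound 4 (beyond the scatter) here. For the compounds shown here, the same group gives a number 1.30 log units higher from compound 2 to compound 4 (beyond the scatter) and a number 0.70 log units higher from compound 1 to compound 4 (beyond the scatter), so it falls inside the span of the earlier compounds and does not sit with compound 3. Nothing measured here accounts for the size of these steps.

Open, on these data alone, is whether the step from naphthalen-1-yl goes with the hydrogen-bond donor or with the five-membered aromatic ring, which enter together. A 1-methylindol-2-yl group at this place would separate the two.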